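Working notes: aryl replacement at the amine-bound chain carbon

The source may hold more compounds than are shown below. What is called first, only, known or untested is meant among the compounds shown, and "the series" means these compounds.

Measured so far:
compound 1: `O=S(=O)(NCCCNCc1cccc2ccccc12)c1cc(C(F)(F)F)cc(C(F)(F)F)c1` — 2700 nM
compound 2: `O=S(=O)(NCCCNCc1ccc(C(F)(F)F)cc1)c1cc(C(F)(F)F)cc(C(F)(F)F)c1` — 1700 nM

Both were run in a functional assay on BXPC-3 cells (Homo sapiens) for inhibition, read by MTT assay, with a stated time of 72 h; on this read-out lower numbers stand for stronger inhibition of growth and higher numbers for weaker inhibition of growth. Going by the values given here, compound 1 stands highest of the two numbers, and the single measured step between the pair is a 1.6-fold lower number from compound 1 to compound 2 (0.20 log units; within the scatter). Compound 3 `COc1ccccc1CNCCCNS(=O)(=O)c1cc(C(F)(F)F)cc(C(F)(F)F)c1` has not been measured. Relative to compound 1 the change is 2-methoxyphenyl in place of naphthalen-1-yl on a saturated chain carbon bound to an amine nitrogen. Among the compounds with values here, the one step bearing on it is a 1.6-fold lower number from compound 1 to compound 2 (0.20 log units; within the scatter), an exchange of the aryl group at the same place that stayed within the scatter. On that basis no step beyond the scatter is expected for compound 3, that is a 1.1-fold lower number from compound 1 to compound 3 (0.03 log units; within the scatter). Compound 3 is estimated at 2500 nM, between 1000 nM and 6000 nM.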

Compound 3, concentration for 50% growth inhibition: 1700 nM
The estimate for compound 3 lay 1.5-fold (0.17 log units) above the measured number; the measured number falls inside the stated range.
By their numbers in this assay, from the lowest: compounds 2, 3 and 1 (each within the scatter of the next).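

In this assay the entry of 2-methoxyphenyl gives a 1.6-fold lower number from compound 1 to compound 3 (0.20 log units; within the scatter) and no change at the digits printed from compound 2 to compound 3 (within the scatter) on a saturated chain carbon bound to an amine nitrogen. A third aryl group, this one with a hydrogen-bond acceptor and a single aromatic ring, therefore joins the other two within the scatter, and neither change separates the compounds. No evidence on the cause of this result is at hand.

Still open, on these data alone, is whether a non-aromatic group here, such as cyclohexyl or a carboxylic acid, would give a step beyond the scatter. As far as these compounds go, a longer chain between the two nitrogens is equally open.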